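The source may report more compounds than this note shows. Statements on the series, on what has been measured and on what is new or still open speak of the compounds shown alone.

Measured in a functional assay on MCF7 cells (Homo sapiens) for antiproliferative activity, read by MTT assay; on this read-out higher numbers stand for weaker inhibition and lower numbers for stronger inhibition:
- compound 1 `Fc1ccc(N2CCN(c3nc(-n4ccc5ccccc54)c4ccccc4n3)CC2)cc1`: 50 ug/mL
- compound 2 `c1ccc2c(c1)ccn2-c1nc(N2CCNCC2)nc2ccccc12`: 14.1 ug/mL

Of these two, compound 2 has the lower number and is therefore the stronger inhibitor, with a gap to the other compound that lies beyond the usual scatter. The next compound, compound 3 `c1ccc(N2CCN(c3nc(-n4ccc5ccccc54)c4ccccc4n3)CC2)cc1`, differs from compound 2 by a single change: phenyl in place of hydrogen on an amine nitrogen in a ring.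

Going by the values given here, only one measured step bears on this change: a 3.5-fold lower number from compound 1 to compound 2 (0.55 log units; beyond the scatter). That modest step replaced 4-fluorophenyl with hydrogen on the same ring nitrogen. Compound 3 goes the opposite way, placing phenyl on that nitrogen. Read backwards, the step from compound 1 suggests that the number will rise in this assay by a similar amount, beyond the scatter. Among the compounds with values here, this rests on one pair of compounds, and no measured pair compares phenyl directly with 4-fluorophenyl, so the range must stay wide.

The expected change is a 2.8-fold higher number from compound 2 to compound 3 (0.45 log units; beyond the scatter). For compound 3 the estimated value is 40 ug/mL, with an expected range of 18 ug/mL to 90 ug/mL.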

Compound 3, half-maximal inhibitory concentration: 50 ug/mL
For compound 3 the middle estimate is 1.3-fold (0.10 log units) below the measured one; measured number inside the range.
By their numbers in this assay, from the lowest: compound 2; then compounds 1 and 3 (each within the scatter of the next).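

In this assay, phenyl on the amine nitrogen in the ring gives a 3.5-fold higher number from compound 2 to compound 3 (0.55 log units; beyond the scatter). This matches in size the earlier step between compound 1 and compound 2, which carries 4-fluorophenyl on that same nitrogen. The fluoro itself makes no visible difference here: hydrogen in its place gives no change at the digits printed from compound 1 to compound 3 (within the scatter) and keeps that result within the scatter, so among these three compounds the clear divide lies between hydrogen on the nitrogen in compound 2 and a benzene-type ring on it in compound 1 and compound 3. Nothing available explains why the two ring-bearing compounds are the weaker inhibitors.

From the compounds shown here alone, with only hydrogen, phenyl and 4-fluorophenyl on this nitrogen, it remains open whether a small methyl group, a longer chain or an acetyl group would stay close to compound 2 or fall with compound 1 and compound 3. Going by these compounds, it is also open whether the phenyl ring is as indifferent to other groups, such as chloro or methoxy, as it is to fluoro.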